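Swapping One Side Chain on a Slowly Cleared Compound

The compounds below may be only part of what the source reports. "The series", "measured", "known", "first", "only" and "open" are said of these compounds alone.

Compound 1 `COCCc1nc2nc(C)cc(Nc3ccc(S(F)(F)(F)(F)F)cc3)n2n1`: 11.5 mL.min-1.g-1
Compound 2 `CCc1nc2nc(C)cc(Nc3cccc(Cl)c3)n2n1`: 78.3 mL.min-1.g-1

In an in vitro ADME assay on microsomes from liver (Homo sapiens) for metabolic stability (a higher number here means faster removal of the compound, a lower number slower removal), compound 1 holds the lower of the two numbers, and compound 2 stands at 78.3 mL.min-1.g-1, a gap beyond the usual scatter. These two compounds differ in more than one place, so their gap cannot be pinned on any single change. Compound 3 `CSc1nc2nc(C)cc(Nc3ccc(S(F)(F)(F)(F)F)cc3)n2n1` keeps the core of compound 1 but carries methylsulfanyl in place of 2-methoxyethyl on an aromatic carbon. Among the measured compounds shown here, no measured pair shows this change, so the only anchor is compound 1 at 11.5 mL.min-1.g-1. The expected result is a 1.4-fold higher number from compound 1 to compound 3 (0.14 log units; within the scatter), which would be no step beyond the scatter. For compound 3 the estimated value is 16 mL.min-1.g-1, with an expected range of 7 mL.min-1.g-1 to 40 mL.min-1.g-1.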

Compound 3, intrinsic clearance in microsomes: 22.4 mL.min-1.g-1
For compound 3 the middle estimate is 1.4-fold (0.15 log units) below the measured one; measured number inside the range.
By their numbers in this assay, from the lowest: compounds 1 and 3 (each within the scatter of the next); then compound 2.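

In this assay, methylsulfanyl in place of 2-methoxyethyl on an aromatic carbon gives a 1.9-fold higher number from compound 1 to compound 3 (0.29 log units; within the scatter), so this single change leaves the two compounds within the scatter of each other. Among the compounds shown here, this is the first comparison that isolates this position, which lies between two ring nitrogen atoms, and it shows that the core of compound 1 can carry either side chain without a step beyond the scatter. No measurement available here accounts for this result.

From the compounds shown here alone, with only these two side chains compared on this core, it remains open how an amine, a carboxylic acid or a longer chain on this carbon would read in this assay. The compounds shown also leave open how much of the gap separating compound 2 from compounds 1 and 3 belongs to this position and how much to the other place where they differ.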